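Chain Length and Chlorine Position in Hydroxamate Antiproliferatives

The source may hold more compounds than are shown below. What is called first, only, known or untested is meant among the compounds shown, and "the series" means these compounds.

Four hydroxamic acids built on one shared core were compared in a functional assay on Jurkat cells (Homo sapiens) for antiproliferative activity, read by MTT assay, with a stated time of 48 h; on this read-out higher numbers stand for weaker inhibition and lower numbers for stronger inhibition. Compound 2 `O=C(CCCCCn1cc(Nc2ncc(Cl)c(Nc3cccc(Cl)c3)n2)cn1)NO` gives 50 nM, and compound 1 `O=C(CCCCCCn1cc(Nc2ncc(Cl)c(Nc3cccc(Cl)c3)n2)cn1)NO` gives 100 nM; the two differ by (hydroxycarbamoyl)methyl in place of hydroxycarbamoyl on a saturated chain carbon, five bonds along the chain from an aromatic nitrogen, a step of a 2.0-fold higher number from compound 2 to compound 1 (0.30 log units; within the scatter). Compound 3 `O=C(CCCCCn1cc(Nc2ncc(Cl)c(Nc3ccccc3Cl)n2)cn1)NO` differs from compound 2 by 2-chlorophenyl in place of 3-chlorophenyl on a nitrogen on an aromatic ring, and in this assay compound 3 gives 310 nM, a step of a 6.2-fold higher number from compound 2 to compound 3 (0.79 log units; beyond the scatter). Compound 4 `O=C(CCCCCCn1cc(Nc2ncc(Cl)c(Nc3ccccc3Cl)n2)cn1)NO` has not yet been measured; it differs from compound 3 by (hydroxycarbamoyl)methyl in place of hydroxycarbamoyl on a saturated chain carbon, five bonds along the chain from an aromatic nitrogen, the same kind of change as that from compound 2 to compound 1, at a place described in the same words. Compound 4 is therefore expected to show a 1.9-fold higher number from compound 3 to compound 4 (0.29 log units; within the scatter), because a 2.0-fold higher number from compound 2 to compound 1 (0.30 log units; within the scatter) was the size of the same change. The estimate for compound 4 is 600 nM, between 250 nM and 1500 nM.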

Compound 4, half-maximal inhibitory concentration: 250 nM
Compound 4: the middle estimate sits 2.4-fold (0.38 log units) above what was measured, and the stated range covers the measured number.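

On the core bearing 2-chlorophenyl, (hydroxycarbamoyl)methyl in place of hydroxycarbamoyl gave a 1.2-fold lower number from compound 3 to compound 4 (0.09 log units; within the scatter), and this step does not differ from its earlier counterpart: the same change on two cores in this assay, a 2.0-fold higher number (0.30 log units; within the scatter) from compound 2 to compound 1 and a 1.2-fold lower number (0.09 log units; within the scatter) from compound 3 to compound 4, 2.5-fold (0.39 log units) apart, within the scatter of two such steps. Likewise, 2-chlorophenyl in place of 3-chlorophenyl on the longer chain gave a 2.5-fold higher number from compound 1 to compound 4 (0.40 log units; beyond the scatter), again in agreement with the earlier step: the same change on two cores in this assay, a 6.2-fold higher number (0.79 log units; beyond the scatter) from compound 2 to compound 3 and a 2.5-fold higher number (0.40 log units; beyond the scatter) from compound 1 to compound 4, 2.5-fold (0.39 log units) apart, within the scatter of two such steps. Both changes therefore carried across these two cores within the scatter, but two pairs do not establish a fixed step size or show that either change would carry to other cores in the series.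

The compounds shown leave open how a still longer chain would behave in this assay. They also leave open the effect of a carboxylic acid in place of the hydroxycarbamoyl group.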